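From compound 2 to compound 4: hydrogen for chloro

The source may report more compounds than this note shows. Statements on the series, on what has been measured and on what is new or still open speak of the compounds shown alone.

Measured so far in a physicochemical assay for inhibition, with a stated time of 7 days (on this read-out lower numbers stand for stronger inhibition and higher numbers for weaker inhibition), as follows:
compound 1 `O=C(Nc1ccc(Br)cc1)Nc1cccc(Cl)c1` gives 6400 nM here
compound 2 `Cc1ccc(C)c(NC(=O)Nc2cccc(Cl)c2)c1` gives "not active" (no number reported) here
compound 3 `Cc1ccc(NC(=O)Nc2cccc(Cl)c2)cc1C` gives "not active" (no number reported) here

Compound 2 has no single number on this read-out. It is reported as "not active" (no number reported) and so cannot be placed on a numerical scale. Compound 3 stands the same way, as "not active" (no number reported) in the record. Of the three, only compound 1 carries a number, 6400 nM in this assay.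

Compound 4 `Cc1ccc(C)c(NC(=O)Nc2ccccc2)c1` has not yet been measured. It is related to compound 2 by one change (hydrogen in place of chloro on an aromatic carbon), with hydrogen in place of chloro on an aromatic carbon, meta to a large group. For the measured compounds named here, no step between measured compounds gauges this change, so its size can only be expected. Starting from compound 2 at "not active" (no number reported) in the record, no clear gain in inhibition is expected, and compound 4 may well also go without a number. Any number it does receive is expected to lie on the weak side of compound 1 at 6400 nM on this scale. If a number is reported, the estimated value for compound 4 is 20000 nM (expected range 7000 nM to 60000 nM).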

Compound 4, half-maximal inhibitory concentration: "not active" (no number reported)
No number was reported for compound 4; no gap can be computed for the estimate.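

In this assay, compound 2 and compound 4 are both reported as not active, without a number, so no step can be read between them. No measured evidence bears on this result. The compounds shown leave open how large an effect, if any, hydrogen in place of chloro has on inhibition.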